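A few compounds are considered here, and "the series" means these few. Any claim that something is new, unique, unknown or untested is made for them only; others in the source may bear on it.

Measured compounds in the series:
- compound 1, `Cc1cccc(NC(=O)c2cccc(/C=C3\CC(=O)N(c4ccccc4)C3=O)c2)c1`: > 100000 nM in an ADME assay on HCT-116 cells (Homo sapiens) for cytotoxicity, read by MTT assay, with a stated time of 72 h; a higher number here means a weaker inhibitor, a lower number a stronger inhibitor
- compound 2, `COc1ccc(NC(=O)c2cccc(/C=C3\CC(=O)N(c4ccccc4)C3=O)c2)cc1`: > 100000 nM in this assay

Compound 1 reaches only a limit of the assay, > 100000 nM. Compound 2 likewise reports only a limit of the assay, > 100000 nM, so compound 2 stands at the unreadable end of the numbers shown, and the one other value shown sits at the same limit (the limit of > 100000 nM in this assay, at which 2 of the 2 values shown sit). The step that the two limits leave unreadable from compound 1 to compound 2 is therefore not readable in size or direction.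

Compound 3, `O=C(Nc1cccc(F)c1)c1cccc(/C=C2\CC(=O)N(c3ccccc3)C2=O)c1`, is not yet measured. The change is 3-fluorophenyl in place of 4-methoxyphenyl on an amide-type nitrogen. Going by the values given here, the only measured step, the one from compound 1 to compound 2, bears on the same position but gives no readable size, so no direction beyond the scatter can be drawn from it. Both neighbours at this position sit at the limit (the limit of > 100000 nM in this assay, at which 2 of the 2 values shown sit), and compound 3 is expected to do the same, with an estimated 150000 nM (range 50000 nM to 500000 nM), an expected step that the limit leaves unreadable from compound 2 to compound 3.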

Compound 3, half-maximal inhibitory concentration: > 100000 nM
Compound 3: only a limit was reported; the forecaster's own chance of this, stated with the estimate: 85%; the middle value does not contradict the limit.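

In this assay, going by these compounds alone, compound 3 gives > 100000 nM as a limit of the assay and not a number, so no step among compound 1, compound 2 and compound 3 can be read: the limit of > 100000 nM in this assay, at which 3 of the 3 values shown sit.

The compounds shown leave open whether any group on the amide-type nitrogen gives a readable value in this assay at all.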